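A few compounds are considered here, and "the series" means these few. Any claim that something is new, unique, unknown or untested is made for them only; others in the source may bear on it.

Measured so far in a functional assay on UACC-62 cells (Homo sapiens) for inhibition, read by sulforhodamine B assay, with a stated time of 48 h; a lower number here means a stronger inhibitor of growth, a higher number a weaker inhibitor of growth:
compound 1, `C=C(C)[C@@H]1CC=C(Cn2cc(COc3cccc(C4NC(=O)NC(C)=C4C(=O)OCC)c3)nn2)CC1`, 22900 nM
compound 2, `C=C(C)[C@@H]1CC=C(Cn2cc(COc3cc(C4NC(=O)NC(C)=C4C(=O)OCC)ccc3OC)nn2)CC1`, 37800 nM
compound 3, `C=C(C)[C@@H]1CC=C(Cn2cc(COc3ccc(C4NC(=O)NC(C)=C4C(C)=O)cc3)nn2)CC1`, 20500 nM

Compound 4, `C=C(C)[C@@H]1CC=C(Cn2cc(COc3ccc(C4NC(=O)NC(C)=C4C(C)=O)cc3OC)nn2)CC1`, is not yet measured. It differs from compound 3 by methoxy in place of hydrogen on an aromatic carbon. The same kind of change separates compound 1 from compound 2, (methoxy in place of hydrogen on an aromatic carbon), and there the step was a 1.7-fold higher number from compound 1 to compound 2 (0.22 log units; within the scatter). The two changes are of the same kind but not the same: in compound 4 the entering group sits ortho to a large group and meta to a large group, whereas in compound 2 it sits ortho to a large group and para to a large group. The difference between the core of compound 1 and the core of compound 3 is not broken down here; in this assay the values of compound 1 and compound 3 lie within the scatter of each other. A step of a 1.7-fold higher number from compound 3 to compound 4 (0.22 log units; within the scatter) is expected, resting on the measured step of a 1.7-fold higher number from compound 1 to compound 2 (0.22 log units; within the scatter). For compound 4 in this assay the estimate is 34000 nM, with an expected range from 17000 nM to 70000 nM.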

Compound 4, concentration for total growth inhibition: 3830 nM
The estimate for compound 4 lay 8.9-fold (0.95 log units) above the measured number, outside the stated range (below it).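

In this assay, methoxy in place of hydrogen on an aromatic carbon gives a 5.4-fold lower number from compound 3 to compound 4 (0.73 log units; beyond the scatter). The change therefore does not carry over unchanged from one core to the other: the same change on two cores in this assay, a 1.7-fold higher number (0.22 log units; within the scatter) from compound 1 to compound 2 and a 5.4-fold lower number (0.73 log units; beyond the scatter) from compound 3 to compound 4, 8.8-fold (0.95 log units) apart, beyond the scatter of two such steps

Going by these compounds alone, the gap is not assigned to any one difference: the cores differ, the methoxy of compound 4 sits meta to a large group, a placement compound 2 does not share, and each core supplies only one pair.

Open, from the compounds shown here alone, is whether ethoxy, hydroxyl or fluorine at the same place on compound 3 would give a step like that to compound 4. Also open, going by these compounds, is whether methoxy at that same place on the core of compound 1 would do so.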